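A few compounds are considered here, and "the series" means these few. Any claim that something is new, unique, unknown or untested is made for them only; others in the source may bear on it.

Measured so far in a functional assay on MCF7 cells (Homo sapiens) for inhibition, read by MTT assay, with a stated time of 72 h; a higher number here means a weaker inhibitor, a lower number a stronger inhibitor:

- compound 1 `COc1cc(-c2nc(SCc3cn(CC(=O)NC(=O)Nc4ccccn4)nn3)nc(Nc3ccc(C(C)C)cc3)c2C#N)cc(OC)c1OC` gives 30900 nM
- compound 2 `COc1cc(-c2nc(SCc3cn(CC(=O)NC(=O)Nc4ccccn4)nn3)nc(Nc3cccc(C(F)(F)F)c3)c2C#N)cc(OC)c1OC` gives 8140 nM

Going by the values given here, compound 2 holds the lower of the two numbers, and the only measured step, a 3.8-fold lower number from compound 1 to compound 2 (0.58 log units; beyond the scatter), separates it from compound 1 by more than the usual scatter. That step exchanges the whole aryl group on the ring nitrogen, so it does not isolate the substituent on that ring from its position.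

Compound 3 `COc1cc(-c2nc(SCc3cn(CC(=O)NC(=O)Nc4ccccn4)nn3)nc(Nc3cccc(Cl)c3)c2C#N)cc(OC)c1OC` keeps everything of compound 2 except (chloro in place of trifluoromethyl on an aromatic carbon). Among the compounds with values here, no measured step in this assay bears directly on this exchange; the one known step is of modest size and concerns a different pair of aryl groups. With no precedent in either direction, the expected step from compound 2 to compound 3 is a 1.2-fold higher number from compound 2 to compound 3 (0.09 log units; within the scatter), that is, nothing beyond the scatter. Compound 3 is therefore estimated at 10000 nM, with a range from 4000 nM to 25000 nM.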

Compound 3, half-maximal inhibitory concentration: 24000 nM
For compound 3 the middle estimate is 2.4-fold (0.38 log units) below the measured one; measured number inside the range.
By their numbers in this assay, from the lowest: compound 2; then compounds 3 and 1 (each within the scatter of the next).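

In this assay, going by these compounds alone, the exchange of trifluoromethyl for chloro on an aromatic carbon is the first step that alters this substituent alone, and a 2.9-fold higher number from compound 2 to compound 3 (0.47 log units; beyond the scatter) shows that the number responds to it. With a 1.3-fold lower number from compound 1 to compound 3 (0.11 log units; within the scatter) as the reading for 3-chlorophenyl in place of 4-isopropylphenyl on the nitrogen, those two aryl groups are not separated, and only 3-(trifluoromethyl)phenyl stands apart among the three. Nothing available accounts for the difference between trifluoromethyl and chloro.

The compounds shown leave open whether 4-(trifluoromethyl)phenyl would keep the lower number of 3-(trifluoromethyl)phenyl, which would separate the substituent from its position. Also open, as far as these compounds go, is how a methoxy group, an amine or a carboxylic acid would read in place of trifluoromethyl on that aromatic carbon.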